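The source may report more compounds than this note shows. Statements on the series, on what has been measured and on what is new or still open speak of the compounds shown alone.

Compound 2 `Cc1ccc(Nc2ncc(C(F)(F)F)c(N3Cc4cccc(N(C)S(C)(=O)=O)c4C3)n2)cc1C` is a weak growth inhibitor. In a functional assay on U-87MG ATCC cells for antiproliferative activity against U-87 MG (Homo sapiens), read by spectrophotometry, with a stated time of 2 days (a higher number here means a weaker inhibitor of growth, a lower number a stronger inhibitor of growth), compound 2 gives only a limit of the assay, > 30000 nM. Its close relative compound 1 `CN(c1cccc2c1CN(c1nc(Nc3cc(Cl)cc(C(F)(F)F)c3)ncc1C(F)(F)F)C2)S(C)(=O)=O` has a different aryl group, and in this assay compound 1 gives 5500 nM; the step of an at least 5.4-fold higher number from compound 1 to compound 2 (0.73 log units; beyond the scatter) is the only measured one here, and it rests on (the limit of > 30000 nM in this assay, at which 1 of the 2 values shown sits). Compound 3 `COc1cc(Nc2ncc(C(F)(F)F)c(N3Cc4cccc(N(C)S(C)(=O)=O)c4C3)n2)cc(C(F)(F)F)c1` takes the next step: 3-methoxy-5-(trifluoromethyl)phenyl in place of 3,4-dimethylphenyl on a nitrogen on an aromatic ring. Because the measured step of an at least 5.4-fold higher number from compound 1 to compound 2 (0.73 log units; beyond the scatter) was beyond the scatter and weakened growth inhibition when the 3-chloro-5-(trifluoromethyl)phenyl left, bringing back a trifluoromethyl-bearing ring is expected to move the number down. Compound 3 is expected to give about 9000 nM, within 3000 nM to 30000 nM. That expectation means a step of an at least 3.3-fold lower number from compound 2 to compound 3 (0.52 log units; beyond the scatter).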

Compound 3, concentration for 50% growth inhibition: > 30000 nM
Compound 3: a limit, no number; the forecaster's own chance of this, stated with the estimate: 25%; at least 3.3-fold (0.52 log units) between middle value and limit.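

With the trifluoromethyl kept on the ring, methoxy in place of chloro on an aromatic carbon still costs growth inhibition in this assay: the change gives an at least 5.4-fold higher number from compound 1 to compound 3 (0.73 log units; beyond the scatter). So a trifluoromethyl on this ring does not by itself preserve the activity of compound 1. The step between compound 2 and compound 3 cannot be read, because both sit at the same limit of the assay: the limit of > 30000 nM in this assay, at which 2 of the 3 values shown sit.

Left open is whether bromo or a nitrile in place of that chloro would hold growth inhibition near that of compound 1. As far as these compounds go, it also remains open whether compound 2 and compound 3 differ at all.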